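From Iodo to Isobutyl on the Sulfonamide Aryl Ring

The source may hold more compounds than are shown below. What is called first, only, known or untested is meant among the compounds shown, and "the series" means these compounds.

Compound 2 `O=C1NCCN1c1ccc(S(=O)(=O)Nc2ccc(I)cc2)cc1` is the weaker of the two measured compounds: in a functional assay on HT-29 cells (Homo sapiens) for antiproliferative activity, read by sulforhodamine B assay, with a stated time of 48 h (a lower number here means a stronger inhibitor, a higher number a weaker inhibitor), compound 2 gives 650 nM, the highest of the two numbers recorded. Going by the values given here, its nearest neighbour is compound 1 `Cc1cccc(NS(=O)(=O)c2ccc(N3CCNC3=O)cc2)c1`, which in this assay gives 110 nM; the only measured step, a 5.9-fold higher number from compound 1 to compound 2 (0.77 log units; beyond the scatter), separates them. Compound 3 `CC(C)Cc1ccc(NS(=O)(=O)c2ccc(N3CCNC3=O)cc2)cc1` has not yet been measured. It differs from compound 2 in one place: isobutyl in place of iodo on an aromatic carbon. Among the compounds with values here, no measured step exchanges a group at this same place while keeping all else fixed; the step of a 5.9-fold higher number from compound 1 to compound 2 (0.77 log units; beyond the scatter) changed both the group and where it sits, so it bears on the new change only loosely, showing that the substituent on this ring can move the number beyond the scatter. With no closer guide, compound 3 is expected to land near compound 2, perhaps with a somewhat lower number. The expected step is a 1.6-fold lower number from compound 2 to compound 3 (0.21 log units; within the scatter), within the scatter. Compound 3 is therefore estimated at 400 nM, within a range from 100 nM to 1600 nM.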

Compound 3, half-maximal inhibitory concentration: > 1000 nM
Compound 3: a limit, no number; the forecaster's own chance of this, stated with the estimate: 5%; middle value at least 2.5-fold (0.39 log units) from the limit.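

In this assay compound 3 gives > 1000 nM, which is a limit of the assay and not a number, and it is the only limit among the values shown: the limit of > 1000 nM in this assay, at which 1 of the 3 values shown sits.

The earlier step changed both the group and where it sits, whereas this one holds the place fixed, on an aromatic carbon para to a large group. The step of an at least 1.5-fold higher number from compound 2 to compound 3 (0.18 log units; that floor lies within the scatter) shows that, at this place, isobutyl in place of iodo, with four carbon atoms entering and one iodine leaving, brings no lower number. On these data alone, the floor of that step lies within the scatter, however, so how far apart the two compounds really stand remains unknown, and the data give no reason for the result.

What the compounds shown leave open is how compound 3 would read as an actual number rather than a limit, and whether the result reflects isobutyl alone or holds for other groups at this place. Nor do they show how an amine, a hydroxyl or a carboxylic acid on this same aromatic carbon would read in this assay.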